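This account rests on a few compounds, and the source may have more. Where it says the series, first, only, none or still open, it means among the compounds named here.

Working notes on the series. The shared core is that of compound 1 `O=CCN1N=C(c2ccc3ccccc3c2)CC1c1ccccc1`, which in a functional assay on IMR-32 cells (Homo sapiens) for cytotoxicity, read by sulforhodamine B assay, with a stated time of 48 h (a lower number here means a stronger inhibitor, a higher number a weaker inhibitor), gives 10000 nM. Compound 2 `COc1ccc(C2CC(c3ccc4ccccc4c3)=NN2CC=O)cc1O` gives 1490 nM, and compound 3 `O=CCN1N=C(c2ccc3ccccc3c2)CC1c1cccc(Br)c1` gives 9870 nM. Compound 3 thus stands second highest of the three numbers, its nearest neighbour being compound 1 and its furthest compound 2.

The next step goes to compound 4 `O=CCN1N=C(c2ccc3ccccc3c2)CC1c1ccco1`, with the change (furan-2-yl in place of 3-bromophenyl on a saturated ring carbon). The bearing steps are those at the same saturated ring carbon: a 6.7-fold lower number from compound 1 to compound 2 (0.83 log units; beyond the scatter) and a 6.6-fold higher number from compound 2 to compound 3 (0.82 log units; beyond the scatter). Among the measured compounds shown here, the only swap that moved the number was the one introducing 3-hydroxy-4-methoxyphenyl; the bromo-for-hydrogen exchange, a 1.0-fold lower number from compound 1 to compound 3 (0.01 log units; within the scatter), did nothing beyond the scatter. Furan-2-yl carries no hydroxy or methoxy group, so the expectation is a step of at most modest size in this assay, direction uncertain, more likely none beyond the scatter.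

Compound 4 is therefore estimated at 8000 nM, in the range 3000 nM to 15000 nM, corresponding to an expected step of a 1.2-fold lower number from compound 3 to compound 4 (0.09 log units; within the scatter).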

Compound 4, half-maximal inhibitory concentration: 11000 nM
Compound 4: middle estimate off by 1.4-fold (0.14 log units), on the low side; the range from low to high includes it.
By their numbers in this assay, from the lowest: compound 2; then compounds 3, 1 and 4 (each within the scatter of the next).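

In this assay, furan-2-yl on this saturated ring carbon gives a 1.1-fold higher number from compound 3 to compound 4 (0.05 log units; within the scatter) and a 1.1-fold higher number from compound 1 to compound 4 (0.04 log units; within the scatter), so swapping a six-membered aromatic ring of carbon only for a five-membered aromatic ring with a hetero atom leaves the number within the scatter. The step of a 7.4-fold higher number from compound 2 to compound 4 (0.87 log units; beyond the scatter) shows that compound 2 alone stands apart, while compounds 1, 3 and 4 form one group with no order among them. Nothing measured accounts for this separation of compound 2.

The compounds shown leave open whether the hydroxy group or the methoxy group of compound 2 carries its step, as neither appears alone here. Also open, on these data alone, is whether an amine or a carboxylic acid on the phenyl ring at this position would move the number.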